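A few compounds are considered here, and "the series" means these few. Any claim that something is new, unique, unknown or untested is made for them only; others in the source may bear on it.

Compound 1 `N#CC1=C(N)Oc2c(c3nc4ccccc4nc3c3ccccc23)C12C(=O)N(Cc1cnnn1-c1ccc(Cl)c(Cl)c1)c1ccccc12`: > 50000 nM
Compound 2 `N#CC1=C(N)Oc2c(N)cc3nc4ccccc4nc3c2C12C(=O)N(Cc1cnnn1-c1cccc(Br)c1)c1ccccc12`: > 50000 nM

In an ADME assay on HUVEC cells (Homo sapiens) for antiproliferative activity, read by MTT assay, with a stated time of 48 h (a lower number here means a stronger inhibitor, a higher number a weaker inhibitor), compound 1 gives > 50000 nM, a limit of the assay rather than a number. Compound 2 gives > 50000 nM in this assay, likewise a limit. Compound 2 therefore stands at the limit of > 50000 nM in this assay, at which 2 of the 2 values shown sit, with no number to rank it against compound 1.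

Compound 3 `N#CC1=C(N)Oc2c(N)cc3nc4ccccc4nc3c2C12C(=O)N(Cc1cnnn1-c1ccc(F)c(Cl)c1)c1ccccc12` carries 3-chloro-4-fluorophenyl in place of 3-bromophenyl on an aromatic nitrogen. Within the data shown here, no step between measured compounds is available to calibrate this change, and no shift beyond the scatter is expected in this assay. Compound 3 is expected at 60000 nM, range 25000 nM to 150000 nM, most likely reported again as a limit. The estimated step that the limit leaves unreadable from compound 2 to compound 3 means no change beyond the scatter.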

Compound 3, half-maximal inhibitory concentration: > 50000 nM
Compound 3: no number, only a limit; the forecaster's own chance of this, stated with the estimate: 85%; the middle value lies beyond the limit too.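

No step can be read from compound 2 to compound 3, as both results are limits: the limit of > 50000 nM in this assay, at which 3 of the 3 values shown sit.

From the compounds shown here alone, what the change from 3-bromophenyl to 3-chloro-4-fluorophenyl does to activity, and how compound 2 and compound 3 rank, stays open.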